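The source may report more compounds than this note shows. Statements on the series, on what has been measured and on what is new or still open speak of the compounds shown alone.

In a functional assay on aorta (Rattus norvegicus, strain Sprague-Dawley) (on this read-out lower numbers stand for an effect already at smaller amounts and higher numbers for an effect only at larger amounts of compound), compound 1 `Cc1nn(-c2ccccc2)c2nc(OCc3ccccc3F)c(-c3nc(N)c(N)c(N)n3)cc12` gives 960 nM. Compound 2 `CC(=O)Nc1c(N)nc(-c2cc3c(C)nn(-c4ccccc4)c3nc2OCc2ccccc2F)nc1N`, with acetyl in place of hydrogen on a nitrogen on an aromatic ring, gives 930 nM, and the step of a 1.0-fold lower number from compound 1 to compound 2 (0.01 log units; within the scatter) shows that this substitution leaves the number unchanged within the scatter. Compound 3 `CCCCOC(=O)Nc1c(N)nc(-c2cc3c(C)nn(-c4ccccc4)c3nc2OCc2ccccc2F)nc1N` carries butoxycarbonyl on that nitrogen instead. Compound 3 is reported only as a limit, > 100000 nM, and so it has no exact number.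

Two measured steps lead to compound 3. They are an at least 100-fold higher number from compound 1 to compound 3 (2.01 log units; beyond the scatter) and an at least 100-fold higher number from compound 2 to compound 3 (2.03 log units; beyond the scatter), and both are large. Compound 4 `Cc1nn(-c2ccccc2)c2nc(OCc3ccccc3F)c(-c3nc(N)c(NC(=O)OC4CCCC4)c(N)n3)cc12` keeps the carbonyl and its oxygen and alters only the group on that oxygen, with cyclopentyl in place of butyl on an oxygen next to a carbonyl group. Within the data shown here, no measured step exchanges one such group for another, so the expectation rests on analogy. Compound 4 retains the feature introduced in the step of an at least 100-fold higher number from compound 2 to compound 3 (2.03 log units; beyond the scatter), and it is therefore expected to stay with compound 3 at the high end of this assay, with no step beyond the scatter. The expected change is a number no higher from compound 3 to compound 4 (the limit leaves the size open), although the limit on compound 3 makes its size uncertain. For compound 4, the estimated value is 100000 nM, with an expected range of 8000 nM to 300000 nM.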

Compound 4, half-maximal effective concentration: > 100000 nM
Compound 4: a limit, no number; the forecaster's own chance of this, stated with the estimate: 65%; the middle value sits exactly at the limit.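

In this assay compound 4 is reported only as a limit, > 100000 nM, so like compound 3 it has no exact number, and the step between these two compounds cannot be read. What compound 4 adds is that the high end of this read-out is not tied to the butyl chain: with cyclopentyl on the oxygen next to a carbonyl group, a five-membered ring replaces the open chain and the outcome is again an at least 100-fold higher number from compound 2 to compound 4 (2.03 log units; beyond the scatter), and likewise an at least 100-fold higher number from compound 1 to compound 4 (2.01 log units; beyond the scatter), both large and both beyond the scatter. Any difference between butyl and cyclopentyl at this position therefore stays out of sight, as both compounds rest on the same ceiling: the limit of > 100000 nM in this assay, at which 2 of the 4 values shown sit.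

The compounds shown leave open whether a smaller group on that oxygen, such as methyl, or a chain ending in an amine, would bring the number back towards those of compound 1 and compound 2. They also leave open whether a butanoyl group, which has a carbon chain on the carbonyl with no oxygen, would stay with compound 2 or move with compound 4.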